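A few compounds are considered here, and "the series" means these few. Any claim that something is new, unique, unknown or untested is made for them only; others in the source may bear on it.

Measured so far:
Compound 1, `O=[N+]([O-])c1ccc(CSc2nc(NC3CC3)nc3c2ncn3[C@@H]2O[C@H](CO)[C@@H](O)[C@H]2O)cc1`: in an assay on K562 cells for displacement of a labelled ligand from Equilibrative nucleoside transporter 1 (Homo sapiens), read by flow cytometry, with a stated time of 45 min (a lower number here means a stronger inhibitor, a higher number a weaker inhibitor), compound 1 gives 25 nM.
Compound 2, `O=[N+]([O-])c1ccc(CSc2nc(NCCO)nc3c2ncn3[C@@H]2O[C@H](CO)[C@@H](O)[C@H]2O)cc1`: in this assay compound 2 gives 86 nM.
Compound 3, `O=[N+]([O-])c1ccc(CSc2nc(I)nc3c2ncn3[C@@H]2O[C@H](CO)[C@@H](O)[C@H]2O)cc1`: in this assay compound 3 gives 11 nM.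

Compound 3 holds the lowest number of the three; the nearest is compound 1, the furthest compound 2. Compound 4, `CC(=O)Nc1nc(SCc2ccc([N+](=O)[O-])cc2)c2ncn([C@@H]3O[C@H](CO)[C@@H](O)[C@H]3O)c2n1`, differs from compound 3 by acetamido in place of iodo on an aromatic carbon. Within the data shown here, two measured steps bear on this, both replacing a group attached through nitrogen with iodo at the same position: a 2.3-fold lower number from compound 1 to compound 3 (0.36 log units; beyond the scatter) and a 7.8-fold lower number from compound 2 to compound 3 (0.89 log units; beyond the scatter). Reinstating a nitrogen-attached group is therefore expected to move the number back upward in this assay, by a modest step, a 4.5-fold higher number from compound 3 to compound 4 (0.66 log units; beyond the scatter). Compound 4 is expected near 50 nM, within 20 nM to 130 nM.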

Compound 4, inhibition constant: 34 nM
Beside the measured number, compound 4's estimate is 1.5-fold (0.17 log units) above it; low and high end bracket the measured number.
By their numbers in this assay, from the lowest: compound 3; then compounds 1 and 4 (each within the scatter of the next); then compound 2.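

With a 3.1-fold higher number from compound 3 to compound 4 (0.49 log units; beyond the scatter) in this assay, acetamido joins cyclopropylamino and (2-hydroxyethyl)amino as a nitrogen-attached group on this aromatic carbon that gives a higher number than iodo. Acetyl on that nitrogen separates from 2-hydroxyethyl, with a 2.5-fold lower number from compound 2 to compound 4 (0.40 log units; beyond the scatter) beyond the scatter, but not from cyclopropyl, with a 1.4-fold higher number from compound 1 to compound 4 (0.13 log units; within the scatter) within it. No measurement shown accounts for these differences. Still open, as far as these compounds go, is whether an unsubstituted amine or a longer acyl chain on this nitrogen would fall with these groups. From the compounds shown here alone, whether bromo or chloro would match iodo also remains unknown.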